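Halogen swap on the benzyl arm of the triazole amide

This account rests on a few compounds, and the source may have more. Where it says the series, first, only, none or still open, it means among the compounds named here.

Two members of the series carry numbers in a functional assay on HeLa cells (Homo sapiens) for antiproliferative activity, read by sulforhodamine B assay, with a stated time of 48 h; a lower number here means a stronger inhibitor of growth, a higher number a weaker inhibitor of growth. Compound 1 `O=C(NCc1cn(Cc2ccc(Cl)cc2)nn1)c1cn(-c2ccccc2)nc1-c1ccc(Cl)cc1` gives 470 nM. Compound 2 `COc1ccc(-c2nn(-c3ccccc3)cc2C(=O)NCc2cn(Cc3ccc(F)cc3)nn2)cc1` gives 500 nM in this assay; this is the higher of the two numbers, yet the gap to compound 1 lies within the scatter, so the two cannot be told apart on these data.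

Compound 3 `COc1ccc(-c2nn(-c3ccccc3)cc2C(=O)NCc2cn(Cc3ccc(Cl)cc3)nn2)cc1` is unmeasured. It differs from compound 2 by chloro in place of fluoro on an aromatic carbon. Among the measured compounds shown here, no measured pair shows this change on its own, and compound 1, which already carries the 4-chlorobenzyl group, also differs from compound 2 in the other aryl group, so it offers no clean model for the step. The step from compound 2 to compound 3 in this assay is expected to stay within the scatter, with no direction assigned. For compound 3 the estimate in this assay is 450 nM, with a range from 200 nM to 1000 nM. This estimate corresponds to a 1.1-fold lower number from compound 2 to compound 3 (0.05 log units; within the scatter).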

Compound 3, concentration for 50% growth inhibition: 6400 nM
The estimate for compound 3 lay 14-fold (1.15 log units) below the measured number, and the stated range ends below it.
By their numbers in this assay, from the lowest: compounds 1 and 2 (each within the scatter of the next); then compound 3.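

The halogen on the benzyl arm is not a silent position: with the methoxy group in place, chloro in place of fluoro on an aromatic carbon gives a 13-fold higher number from compound 2 to compound 3 (1.11 log units; beyond the scatter) in this assay, although one heavy atom replaces one heavy atom and no hydrogen-bond donor or acceptor enters or leaves. The other aryl group also counts, as with the 4-chlorobenzyl group held fixed, methoxy in place of chloro gives a 14-fold higher number from compound 1 to compound 3 (1.13 log units; beyond the scatter). The 4-chlorobenzyl group therefore goes with a low number in compound 1 and a high number in compound 3, so its standing depends on the group at the other aryl ring.

Open, as far as these compounds go, is how a 4-fluorobenzyl arm behaves alongside the 4-chlorophenyl group, and whether bromo or an amine at the same carbon follows chloro or fluoro. Nothing on hand accounts for the size of these steps.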